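The source may hold more compounds than are shown below. What is called first, only, known or untested is meant among the compounds shown, and "the series" means these compounds.

Compound 1 `COc1cc(C2=NN(C(C)=O)C(c3cc(Cl)cc(Cl)c3)O2)cc(OC)c1OC` was tested in a functional assay on BGC-823 cells (Homo sapiens) for antiproliferative activity, read by MTT assay, tested at 1 uM (on this read-out higher numbers stand for a stronger effect at the one concentration tested and lower numbers for a weaker effect), where compound 1 gives 0%. This is the lowest of the three numbers recorded. The two other compounds share only part of its structure: compound 2 `COc1cc(C(=O)N/N=C/c2cccc(F)c2)cc(OC)c1OC` gives 13.6%, and compound 3 `COc1cc(C(=O)N/N=C/c2cccc(C(F)(F)F)c2)cc(OC)c1OC` gives 17.7%. Compound 1 thus sits beyond the scatter below both compound 2 and compound 3.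

Compound 4 `COc1cc(C2=NN(C(C)=O)C(c3ccc(F)c(F)c3)O2)cc(OC)c1OC` has not yet been measured. It differs from compound 1 in one place: 3,4-difluorophenyl in place of 3,5-dichlorophenyl on a saturated ring carbon. The new group sits on a saturated ring carbon of the five-membered non-aromatic ring of the shared core.

Among the compounds with values here, only one measured step exists, and it is on a different core: a number 4.1 percentage points higher from compound 2 to compound 3 (within the scatter), a swap of one halogen-bearing group for another on an aromatic carbon that changed the read-out by little. Within the data shown here, no measured step covers a change on the core of compound 1 itself, so the expectation rests on that single small step and on the low starting point of compound 1.

A small step is therefore expected, a number 5 percentage points higher from compound 1 to compound 4 (within the scatter), with compound 4 estimated at 5%, within a range from 0% to 20%.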

Compound 4, a percentage reported as inhibition, at one concentration (the size of the read-out at that concentration, not a potency): 18.3%
For compound 4 the middle estimate is 13.3 percentage points below the measured one; the range from low to high includes it.
By their numbers in this assay, from the lowest: compound 1; then compounds 2, 3 and 4 (each within the scatter of the next).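

Within the data shown here, on the saturated ring carbon of the shared core, the attached aryl group matters: in this assay, replacing 3,5-dichlorophenyl with 3,4-difluorophenyl gives a number 18.3 percentage points higher from compound 1 to compound 4 (beyond the scatter) as the first measured change on this core. The two groups have the same heavy-atom count and neither has a hydrogen-bond donor or acceptor, so these counts do not separate them; the difference lies in the halogen and in where the halogens sit on the phenyl ring, and both change in this one swap, so the effect of each cannot be read separately. No measurement shown here explains the rise.

A 3,4-dichlorophenyl or 3,5-difluorophenyl group at this position would show whether the halogen or its placement on the phenyl ring accounts for the step, and a phenyl ring carrying an amine or a carboxylic acid would test groups of a different kind. With only one concentration tested, the numbers also leave open how potent compound 1 and compound 4 are.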